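A few compounds are considered here, and "the series" means these few. Any claim that something is new, unique, unknown or untested is made for them only; others in the source may bear on it.

The series shares one core, seen in compound 1 `Nc1cc(N)c2nc(-c3ccccc3)c(NCc3ccc(Cl)c(Cl)c3)nc2c1`, compound 2 `CCOC(=O)[C@H](CCC(=O)O)NC(=O)c1ccc(Sc2nc3cc(N)cc(N)c3nc2-c2ccccc2)cc1` and compound 3 `Nc1cc(N)c2nc(-c3ccccc3)c(Sc3ccc(F)cc3)nc2c1`, each carrying a phenyl on one side and a varying group on the other. In a functional assay on MOLT-4 cells (Homo sapiens) for inhibition, read by sulforhodamine B assay, with a stated time of 48 h (on this read-out higher numbers stand for weaker inhibition of growth and lower numbers for stronger inhibition of growth), compound 1 gives < 100000 nM, which is a limit of the assay and not a number. In this assay compound 2 gives < 100000 nM, again a limit. In this assay compound 3 gives < 100000 nM, also a limit. Compound 3 thus stands exactly where all the measured values stand: the limit of < 100000 nM in this assay, at which 3 of the 3 values shown sit. No pair of measured compounds differs in a single place; no measured step is available, and no direction of change is shown by any of the three.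

Compound 4 `Nc1cc(N)c2nc(-c3ccccc3)c(Sc3ccc(Cl)c(Cl)c3)nc2c1` has not yet been measured in this assay. It differs from compound 3 as follows: 3,4-dichlorophenyl in place of 4-fluorophenyl on a sulfur. With only limits on hand for every measured compound, the expectation for the step from compound 3 to compound 4 is none beyond the scatter, a step that the limit leaves unreadable from compound 3 to compound 4. Compound 4 is accordingly expected to give 60000 nM in this assay, between 20000 nM and 100000 nM, most probably reported once more as a limit rather than a number.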

Compound 4, concentration for total growth inhibition: < 100000 nM
Compound 4: no number, only a limit (the forecaster's own chance of this, stated with the estimate: 85%); the middle value is on the limit's open side.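

In this assay compound 4 gives < 100000 nM, a limit and not a number. No step can be read from compound 3 to compound 4, because both compounds rest on the same limit: the limit of < 100000 nM in this assay, at which 4 of the 4 values shown sit.

The compounds shown leave open whether any group varied on the shared core changes inhibition of growth at all.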